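This account rests on a few compounds, and the source may have more. Where it says the series, first, only, none or still open, it means among the compounds named here.

The measured compounds, with their values in a functional assay on MDA-MB-231 cells (Homo sapiens) for cytotoxicity, read by MTT assay, with a stated time of 72 h (on this read-out higher numbers stand for weaker inhibition and lower numbers for stronger inhibition), are:

Compound 1, `Cc1ccc(NC(=O)CN2CCN(c3nnc(Cc4ccncc4)c4ccccc34)CC2)c(C)c1`, gives 240 nM.
Compound 2, `O=C(CN1CCN(c2nnc(Cc3ccncc3)c3ccccc23)CC1)Nc1cccc(Br)c1`, gives 1.7 nM.
Compound 3, `O=C(CN1CCN(c2nnc(Cc3ccccc3)c3ccccc23)CC1)Nc1cccc(Br)c1`, gives 3880 nM.

Compound 2 is the most potent of the three. Exchanging the aryl group on the amide, (2,4-dimethylphenyl in place of 3-bromophenyl on an amide-type nitrogen), produces a 140-fold higher number from compound 2 to compound 1 (2.15 log units; beyond the scatter). The two cores differ as described in phenyl in place of pyridin-4-yl on a saturated chain carbon bound to an aromatic carbon, and that change alone gives a 2300-fold higher number from compound 2 to compound 3 (3.36 log units; beyond the scatter), leaving compound 3 with the highest number of the three.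

Compound 4, `Cc1ccc(NC(=O)CN2CCN(c3nnc(Cc4ccccc4)c4ccccc34)CC2)c(C)c1`, combines the core of compound 3 with the amide substituent of compound 1. The change from compound 3 to compound 4 is 2,4-dimethylphenyl in place of 3-bromophenyl on an amide-type nitrogen, and it is the same change as that from compound 2 to compound 1: the groups leaving and entering are identical and the place is described in the same words. Among the compounds with values here, the only precedent is therefore the single step from compound 2 to compound 1. Within the data shown here, the expected step for compound 4 is a 26-fold higher number from compound 3 to compound 4 (1.41 log units; beyond the scatter), because a 140-fold higher number from compound 2 to compound 1 (2.15 log units; beyond the scatter) is the sole measured instance of this change and the estimate is taken to resemble it. Since compound 3 already starts from a high number, the expected result for compound 4 lies where this assay may report only a limit rather than a number. Compound 4 is expected to give 100000 nM, with a likely range from 20000 nM to 600000 nM.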

Compound 4, half-maximal inhibitory concentration: 181000 nM
For compound 4 the middle estimate is 1.8-fold (0.26 log units) below the measured one; measured number inside the range.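

In this assay, 2,4-dimethylphenyl in place of 3-bromophenyl on the amide-type nitrogen again gives a higher number on the phenyl-bearing core, with a 47-fold higher number from compound 3 to compound 4 (1.67 log units; beyond the scatter), and phenyl in place of pyridin-4-yl again gives a higher number with the 2,4-dimethylphenyl amide, with a 750-fold higher number from compound 1 to compound 4 (2.88 log units; beyond the scatter). The direction of the amide change therefore carries from one core to the other, but its size does not carry over unchanged, and the step is smaller on the core of compound 3: the same change on two cores in this assay, a 140-fold higher number (2.15 log units; beyond the scatter) from compound 2 to compound 1 and a 47-fold higher number (1.67 log units; beyond the scatter) from compound 3 to compound 4, 3.0-fold (0.48 log units) apart, beyond the scatter of two such steps. Read from the side of the other change, the same four compounds show the same gap, and this single set of four does not show how large either change would be on a further core or with a further amide substituent: the same change on two cores in this assay, a 2300-fold higher number (3.36 log units; beyond the scatter) from compound 2 to compound 3 and a 750-fold higher number (2.88 log units; beyond the scatter) from compound 1 to compound 4, 3.0-fold (0.48 log units) apart, beyond the scatter of two such steps.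

The compounds shown leave open what a pyridin-3-yl or pyridin-2-yl group would give in place of pyridin-4-yl. They also leave open what an unsubstituted phenyl, a 3-chlorophenyl or a 3-methylphenyl group on the amide-type nitrogen would give, and so whether the loss follows from removing the bromine or from adding the methyl groups.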